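From Allyl to 4-Bromophenyl Near the Assay Limit

The source may report more compounds than this note shows. Statements on the series, on what has been measured and on what is new or still open speak of the compounds shown alone.

Going by the values given here, in a functional assay on HCT-116 cells (Homo sapiens) for antiproliferative activity, read by MTT assay, with a stated time of 72 h (on this read-out lower numbers stand for stronger inhibition and higher numbers for weaker inhibition), compound 1 (`C=CC/N=C1\S/C(=C\c2ccc(OC)cc2)C(=O)N1C`) gives 79300 nM, the only true number available. Compound 2 (`C=C1CN(C)/C(=N/c2ccccc2)S1`) is reported only as a limit, > 100000 nM. Compound 3 (`S=C(Nc1ccccc1)N1C/C(=C/c2ccccc2)S/C1=N\c1ccccc1`) is likewise reported only as a limit, > 100000 nM. Compound 1 therefore stands close to the limit of > 100000 nM in this assay, at which 2 of the 3 values shown sit.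

Compound 4 (`COc1ccc(/C=C2\S/C(=N\c3ccc(Br)cc3)N(C)C2=O)cc1`) keeps the core of compound 1 but carries 4-bromophenyl in place of allyl on a double-bonded nitrogen. Among the compounds with values here, no measured pair shows what this swap does, so only a modest gain in this assay is expected. The expected change is a 2.0-fold lower number from compound 1 to compound 4 (0.30 log units; within the scatter), towards stronger inhibition. For compound 4, the estimated half-maximal inhibitory concentration is 40000 nM, with an expected range of 12000 nM to 100000 nM.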

Compound 4, half-maximal inhibitory concentration: 17000 nM
Beside the measured number, compound 4's estimate is 2.4-fold (0.37 log units) above it; the range from low to high includes it.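

In this assay, the position on a double-bonded nitrogen now has its first measured step: 4-bromophenyl in place of allyl gives a 4.7-fold lower number from compound 1 to compound 4 (0.67 log units; beyond the scatter). The earlier compounds shown here offered no pair differing in one place, so nothing before this showed that a change here could move the number at all. Compound 2 and compound 3 remain limits, not numbers: the limit of > 100000 nM in this assay, at which 2 of the 4 values shown sit.

The compounds shown leave open whether the bromine or the aromatic ring carries this step, which a plain phenyl on the same nitrogen would separate. On these data alone, what an amine or a carboxylic acid on that ring would do also stays open.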